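Swapping Methyl for Trifluoromethyl in Compound 1

This account rests on a few compounds, and the source may have more. Where it says the series, first, only, none or still open, it means among the compounds named here.

Among the compounds with values here, compound 1 `Cc1ccc(Nc2cncc(N3CC4CC(C3)N4)c2)cc1` is measured in an assay on HEK293 cells for displacement of a labelled ligand from Neuronal acetylcholine receptor; alpha3/beta4 (Homo sapiens) (a lower number here means a stronger inhibitor, a higher number a weaker inhibitor), at 1.4 nM, the lowest of the three numbers known. Compound 2 `O=[N+]([O-])c1ccc(Nc2ccc(N3CC4CC(C3)N4)cn2)cc1` gives 25 nM in this assay, and compound 3 `Oc1ccc(Nc2ccc(N3CC4CC(C3)N4)cn2)cc1` gives 165 nM. Within the data shown here, the only single-point step among them, a 6.6-fold higher number from compound 2 to compound 3 (0.82 log units; beyond the scatter), concerns a different substituent on a different core and so bears only loosely on the change to compound 4 `FC(F)(F)c1ccc(Nc2cncc(N3CC4CC(C3)N4)c2)cc1`, which is trifluoromethyl in place of methyl on an aromatic carbon. Among the measured compounds shown here, no measured step here exchanges methyl for trifluoromethyl, so the expectation rests on compound 1 alone. Compound 4 is expected to stay close, with at most a small weakening, an estimated step of a 2.1-fold higher number from compound 1 to compound 4 (0.33 log units; beyond the scatter). Compound 4 is therefore estimated at 3 nM, within a range from 0.8 nM to 12 nM.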

Compound 4, inhibition constant: 1.02 nM
Beside the measured number, compound 4's estimate is 2.9-fold (0.47 log units) above it; measured number inside the range.
By their numbers in this assay, from the lowest: compounds 4 and 1 (each within the scatter of the next); then compound 2; then compound 3.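

In this assay, trifluoromethyl in place of methyl on an aromatic carbon para to a large group gives a 1.4-fold lower number from compound 1 to compound 4 (0.14 log units; within the scatter), so compound 1 and compound 4 cannot be told apart. The earlier compounds shown here offered no such exchange on this core; here, a group of 4 heavy atoms at this place reads the same as one of 1 heavy atom. Nothing shown gives a reason for this outcome. Still open, on these data alone, is how an amine or a carboxylic acid at this place on the core of compound 1 would read, and whether a longer chain would read the same as methyl and trifluoromethyl.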